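Pendant aryl variation on the shared core: compound 4 outlook

The source may report more compounds than this note shows. Statements on the series, on what has been measured and on what is new or still open speak of the compounds shown alone.

Measured compounds in a functional assay on the whole organism with Rattus norvegicus as the target, at a dose of 3 mg/kg by the oral route; on this read-out higher numbers stand for a stronger effect at the one dose given and lower numbers for a weaker effect:
compound 1, `COc1cc(C(=O)Nc2nn[nH]n2)nc(-c2cccc(Cl)c2)c1`, 34%
compound 2, `COc1cc(C(=O)Nc2nn[nH]n2)nc(-c2ccccc2OC)c1`, 68%
compound 3, `COc1ccc(-c2cc(OC)cc(C(=O)Nc3nn[nH]n3)n2)cc1`, 60%

Compound 3 stands second of the three numbers. Its nearest neighbour is compound 2, and the step of a number 8 percentage points lower from compound 2 to compound 3 (within the scatter) lies within the scatter, so the two cannot be ordered. Its furthest neighbour is compound 1, and the step of a number 26 percentage points higher from compound 1 to compound 3 (beyond the scatter) is beyond the scatter, as is the step of a number 34 percentage points higher from compound 1 to compound 2 (beyond the scatter).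

Compound 4, `COc1cc(C(=O)Nc2nn[nH]n2)nc(-c2ccc(N(C)C)cc2)c1`, is not yet measured. It differs from compound 3 by dimethylamino in place of methoxy on an aromatic carbon.

Among the measured compounds shown here, no measured step touches this change. The three measured steps all alter the pendant aryl ring, but none exchanges a methoxy for a dimethylamino. For the measured compounds named here, the only step between two methoxy-bearing compounds, a number 8 percentage points lower from compound 2 to compound 3 (within the scatter), is within the scatter, and that gives no direction for compound 4. The expectation is therefore a step no larger than the scatter in this assay, in no fixed direction, so that the step of a number 2 percentage points lower from compound 3 to compound 4 (within the scatter) is estimated to stay within it. Compound 4 is estimated at 58%, within a range from 38% to 78%.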

Compound 4, a percentage reported as inhibition, in the whole organism at one dose (the size of the read-out at that dose, not a potency): 100%
Compound 4: the middle estimate sits 42 percentage points below what was measured; the measured number lies above the stated range.
By their numbers in this assay, from the lowest: compound 1; then compounds 3 and 2 (each within the scatter of the next); then compound 4.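

In this assay the exchange of methoxy for dimethylamino on the aromatic carbon para to a large group gives a number 40 percentage points higher from compound 3 to compound 4 (beyond the scatter) and is the only step shown that keeps the place fixed and changes the group itself. The step of a number 8 percentage points lower from compound 2 to compound 3 (within the scatter) only relocates the methoxy on the pendant ring, so among these compounds the identity of the group at this carbon has a large effect on the read-out, while the methoxy relocation gives no readable difference. Nothing measured here indicates what in the dimethylamino group accounts for the step.

Still open, from the compounds shown here alone, is whether the step belongs to dimethylamino specifically, which an unsubstituted amine, a diethylamino group or a pyrrolidine ring on the same carbon would help to separate. Also open, going by these compounds, are how dimethylamino behaves at the other places on the pendant ring and, since compound 4 at 100% is a read-out at one dose and not a potency, how it would rank at lower doses.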